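Swapping ethoxy for methyl on an antiproliferative series

The source may hold more compounds than are shown below. What is called first, only, known or untested is meant among the compounds shown, and "the series" means these compounds.

Measured in a functional assay on A2780 cells (Homo sapiens) for antiproliferative activity, read by MTT assay, with a stated time of 48 h; a higher number here means a weaker inhibitor of growth, a lower number a stronger inhibitor of growth:
Compound 1 `COC(=O)N1N=C(c2ccccc2)CC1c1cc(OC)c(OC)c(OC)c1`: 2770 nM
Compound 2 `CCOc1cccc(C2=NN(C(=O)OC)C(c3cc(OC)c(OC)c(OC)c3)C2)c1`: 760 nM

Of these two numbers, compound 2 holds the lower, at 760 nM, and so stands as the stronger inhibitor of growth in this assay. The next compound, compound 3 `COC(=O)N1N=C(c2cccc(C)c2)CC1c1cc(OC)c(OC)c(OC)c1`, keeps the shared core and carries methyl in place of ethoxy on an aromatic carbon. The change sits on a six-membered aromatic ring of carbon only, meta to a large group, and reads 3-ethoxyphenyl to 3-methylphenyl.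

For the measured compounds named here, one measured step bears on this: a 3.6-fold lower number from compound 1 to compound 2 (0.56 log units; beyond the scatter). It concerns the same ethoxy that compound 3 gives up. Going by the values given here, no measured compound carries methyl, so the data do not show how much of that step would remain. Among the compounds with values here, a modest move to a higher number is therefore expected, no larger than that step and possibly within the scatter. The expected change is a 1.7-fold higher number from compound 2 to compound 3 (0.23 log units; within the scatter). For compound 3 the estimated value is 1300 nM, with an expected range of 500 nM to 3000 nM.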

Compound 3, concentration for 50% growth inhibition: 600 nM
Compound 3: middle estimate off by 2.2-fold (0.34 log units), on the high side; measured number inside the range.
By their numbers in this assay, from the lowest: compounds 3 and 2 (each within the scatter of the next); then compound 1.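

In this assay, replacing ethoxy with methyl on this aromatic carbon gives a step that stays within the scatter (a 1.3-fold lower number from compound 2 to compound 3 (0.10 log units; within the scatter)), so compound 2 and compound 3 cannot be ranked against each other. The gain over the unsubstituted compound therefore does not require ethoxy, with its 3 heavy atoms and its oxygen: a methyl of 1 heavy atom, with no hydrogen-bond acceptor, also gives a step beyond the scatter (a 4.6-fold lower number from compound 1 to compound 3 (0.66 log units; beyond the scatter)), and both groups improve on hydrogen at this place. No independent measurement accompanies these numbers, so the result stands without any stated reason.

The compounds shown leave open whether other groups at this place, such as a longer chain like propoxy, a halogen such as chlorine, or an amine, would stay level with methyl and ethoxy or move away from them. They also leave open whether methyl would give a similar step on another carbon of the same ring, since only this one place on that ring has been compared here.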